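The source may report more compounds than this note shows. Statements on the series, on what has been measured and on what is new or still open speak of the compounds shown alone.

Measured compounds:
compound 1 `O=c1oc(-c2ccccc2I)nc2ccccc12` — 16700 nM
compound 2 `O=c1oc(-c2ccccc2C(F)(F)F)nc2ccccc12` — 35400 nM

In an assay on isolated protein for inhibition of complement C1r subcomponent (Homo sapiens) (a lower number here means a stronger inhibitor, a higher number a weaker inhibitor), compound 1 gives 16700 nM, the lowest of the two numbers. Compound 2 is the nearest point of comparison: the step of a 2.1-fold higher number from compound 1 to compound 2 (0.33 log units; beyond the scatter) is modest and arises from trifluoromethyl in place of iodo on an aromatic carbon.

Compound 3 `O=c1oc(-c2ccccc2I)nc2cccc(Cl)c12` differs from compound 1 in one place: chloro in place of hydrogen on an aromatic carbon. The iodo of compound 1 is kept. Among the measured compounds shown here, no measured step bears directly on this change. For the measured compounds named here, the single step known, from compound 1 to compound 2, exchanges the iodo itself and says nothing about a chloro entering on the core in place of hydrogen. The expectation for compound 3 therefore rests on the general observation that one substituent change in this series moved the number only modestly; a step of similar size, in either direction, or none beyond the scatter is expected, with a slight lean toward a lower number.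

For compound 3 the estimate in this assay is 12000 nM, with a range from 4000 nM to 40000 nM, meaning an expected step of a 1.4-fold lower number from compound 1 to compound 3 (0.14 log units; within the scatter).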

Compound 3, half-maximal inhibitory concentration: 13500 nM
Beside the measured number, compound 3's estimate is 1.1-fold (0.05 log units) below it; measured number inside the range.
By their numbers in this assay, from the lowest: compounds 3 and 1 (each within the scatter of the next); then compound 2.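

In this assay, chloro in place of hydrogen on an aromatic carbon of the six-membered aromatic ring of carbon only, part of the fused system of two rings, gives a 1.2-fold lower number from compound 1 to compound 3 (0.09 log units; within the scatter). Unlike a 2.1-fold higher number from compound 1 to compound 2 (0.33 log units; beyond the scatter), which exchanges the iodo itself, this change keeps the iodo and is the first shown on the shared core, and the added chlorine atom leaves the number within the scatter, so this position tolerates chloro in this one comparison. No independent evidence bears on why the number holds at this position with chloro present.

One substituent at one core position cannot show whether the position is generally insensitive, and an amine, a methoxy group or a carboxylic acid on the same carbon would test this more sharply than chloro does. From the compounds shown here alone, it also stays open whether chloro on the core would behave the same way with trifluoromethyl in place of iodo, and whether other carbons of the same ring would accept chloro as this one does.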